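Moving the Fluorine: Expected Maximal Response of Compound 3

The source may hold more compounds than are shown below. What is called first, only, known or untested is meant among the compounds shown, and "the series" means these compounds.

Measured so far:
- compound 1, `Cc1ccc(C(CC/N=C(\N)NCCCc2c[nH]cn2)c2ccccn2)cc1`: 1
- compound 2, `N=C(NCCCc1c[nH]cn1)NCCC(c1ccc(F)cc1)c1ccccn1`: 0.8

Both compounds were tested in a functional assay on muscle tissue for agonist activity at histamine H2 receptor (Cavia porcellus); a higher number here means a larger maximal response, a lower number a smaller maximal response. Compound 1 reaches the full response of the reference agonist, giving 1 in this assay. Compound 2 gives 0.8 in this assay, the lower of the two numbers; the gap to compound 1 lies beyond the usual scatter, so compound 2 truly reaches a smaller maximal response.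

Compound 3, `N=C(NCCCc1c[nH]cn1)NCCC(c1cccc(F)c1)c1ccccn1`, has not yet been measured. It differs from compound 2 only in where the fluorine sits on the aromatic ring: 3-fluorophenyl in place of 4-fluorophenyl on a saturated chain carbon bound to an aromatic carbon and a saturated chain carbon

Within the data shown here, no measured pair shows a comparable change, so there is no direct guide to its effect. Since the atoms are the same and only their arrangement shifts, the step from compound 2 to compound 3 is expected to be small, with no clear direction, and most likely within the scatter, which the estimate no change at the digits printed from compound 2 to compound 3 (within the scatter) reflects. Compound 3 is therefore expected to give about 0.8 in this assay, within a range from 0.6 to 1.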

Compound 3, intrinsic activity: the largest response reached, as a fraction of the reference agonist's: 0.5
Compound 3: middle estimate off by 0.30, on the high side; measured number outside the range, below it.
By their numbers in this assay, from the lowest: compound 3; then compound 2; then compound 1.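

Having the same atoms does not guarantee the same result: in this assay, moving the fluorine from 4-fluorophenyl to 3-fluorophenyl gives a number 0.30 lower from compound 2 to compound 3 (beyond the scatter). For this pair, the maximal response therefore depends on where the fluorine sits on the aromatic ring attached to the saturated chain carbon, something that compound 1 and compound 2 alone could not show, as neither pair member offered a shift of this kind. Nothing available here explains this drop.

This is a single pair with a single substituent, so it cannot establish a general rule for the ring. The compounds shown leave open whether a chlorine atom or a methoxy group would show a similar loss of maximal response when moved in the same way, and whether a 3-methylphenyl group would behave like 3-fluorophenyl.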